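Swapping a carbamate oxygen for sulfur on a shared core

The source may hold more compounds than are shown below. What is called first, only, known or untested is meant among the compounds shown, and "the series" means these compounds.

Of the compounds shown here, three with one shared core have been measured in a functional assay on isolated protein for inhibition of Glucose-dependent insulinotropic receptor (Homo sapiens), read by HTRF and cAMP accumulation; a lower number here means that less compound is needed, a higher number that more compound is needed for the effect. Compound 1 `Cc1nc(S(C)(=O)=O)ccc1Oc1ncnc(OC2CCN(C(=O)OC(C)C)CC2)c1F` gives 21 nM. Compound 2 `Cc1nc(S(C)(=O)=O)ccc1Oc1ncnc(OC2CCN(C(=O)OC3COC3)CC2)c1F` gives 326 nM, and compound 3 `Cc1nc(S(C)(=O)=O)ccc1Oc1ncnc(OC2CCN(C(=O)OC3(C(F)(F)F)COC3)CC2)c1F` gives 29.3 nM. Compound 3 stands second highest of the three numbers; its nearest neighbour is compound 1, within the usual scatter, while compound 2 is furthest, with an 11-fold lower number from compound 2 to compound 3 (1.05 log units; beyond the scatter). The two measured steps show that the group on the oxygen attached to the carbonyl matters: a 16-fold higher number from compound 1 to compound 2 (1.19 log units; beyond the scatter), and adding a trifluoromethyl to that ring reversed the loss, as an 11-fold lower number from compound 2 to compound 3 (1.05 log units; beyond the scatter).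

Compound 4 `Cc1nc(S(C)(=O)=O)ccc1Oc1ncnc(OC2CCN(C(=O)SC3CCC3)CC2)c1F` differs from compound 3 by cyclobutylsulfanyl in place of (3-(trifluoromethyl)oxetan-3-yl)oxy on a carbonyl carbon. Among the measured compounds shown here, no measured step covers a sulfur in this position or a carbon-only four-membered ring, so the expectation rests on the observation that a small unsubstituted ring here, compound 2, was the weak case, whereas isopropyl and the trifluoromethyl-bearing ring were similar. Compound 4 is expected near compound 3, with a 1.2-fold higher number from compound 3 to compound 4 (0.08 log units; within the scatter), estimated at 35 nM, between 8 nM and 150 nM.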

Compound 4, half-maximal effective concentration: 8.51 nM
Beside the measured number, compound 4's estimate is 4.1-fold (0.61 log units) above it; the measured number falls inside the stated range.
By their numbers in this assay, from the lowest: compound 4; then compounds 1 and 3 (each within the scatter of the next); then compound 2.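

With cyclobutylsulfanyl on the carbonyl carbon, compound 4 gives the lowest number of the set in this assay, and all three new steps lie beyond the scatter: (a 3.4-fold lower number from compound 3 to compound 4 (0.54 log units; beyond the scatter)) and (a 2.5-fold lower number from compound 1 to compound 4 (0.39 log units; beyond the scatter)) and (a 38-fold lower number from compound 2 to compound 4 (1.58 log units; beyond the scatter)). Among the compounds shown here, the earlier compounds showed only that a group on the oxygen could match isopropyl, while this result shows that the number at this position can go lower than with isopropoxy, even when a sulfur makes the link. No measured evidence here explains the gain.

Going by these compounds, the sulfur and the carbon-only ring arrive together, so their separate contributions remain unknown. Cyclobutyloxy and isopropylsulfanyl would each vary just one of them, and cyclobutylamino would put a nitrogen at the link.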